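Chlorophenyl Ester Estimated from Methoxyphenyl Analogues

The source may hold more compounds than are shown below. What is called first, only, known or untested is meant among the compounds shown, and "the series" means these compounds.

Measured compounds:
compound 1, `COc1ccc(C(=O)Oc2cc3c(cc2C)[C@@H](C(C)C)CC=C3C)cc1`, 37%
compound 2, `COc1cccc(C(=O)Oc2cc3c(cc2C)[C@@H](C(C)C)CC=C3C)c1`, "not active" (no number reported)
compound 3, `Cc1cc2c(C(C)C)ccc(C)c2cc1OC(=O)c1cccc(C(F)(F)F)c1`, "not active" (no number reported)

In a functional assay on U-251 cells (Homo sapiens) for antiproliferative activity, read by sulforhodamine B assay, with a stated time of 48 h, tested at 50 uM (a higher number here means more inhibition at the concentration tested (going by the name of the read-out), a lower number less inhibition), compound 1 gives 37%. Compound 2 is reported in this assay as "not active" (no number reported), with no number attached, and it is not the only one: compound 3 is likewise reported in this assay as "not active" (no number reported). Compound 2 therefore stands at the bottom of what has been seen, without a figure that could anchor a comparison, while compound 1, which carries a 4-methoxyphenyl in place of its 3-methoxyphenyl, shows measurable inhibition.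

Compound 4, `CC1=CC[C@H](C(C)C)c2cc(C)c(OC(=O)c3ccc(Cl)cc3)cc21`, has not been measured in this assay. It differs from compound 2 at one place: 4-chlorophenyl in place of 3-methoxyphenyl on a carbonyl carbon. Going by the values given here, no step between two measured compounds covers this change, so its size cannot be read off. What the data show is that the one ester on this core with a substituent in the 4-position, compound 1, gives 37%, while compound 2 with its 3-methoxyphenyl is reported as not active. On that basis an upward step from compound 2 beyond the scatter seems plausible but uncertain. Compound 4 is estimated to give 30% in this assay, expected to fall between 8% and 55%.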

Compound 4, a percentage reported as inhibition, at one concentration (the size of the read-out at that concentration, not a potency): 25.6%
Compound 4: middle estimate off by 4.4 percentage points, on the high side; measured number inside the range.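

Compound 4 shows that a chloro group can take the place of methoxy on this aryl ester and still leave a number in this assay, so measurable inhibition on the shared core does not depend on the methoxy group. Going by these compounds alone, the identity of the group still matters: chloro in place of methoxy on an aromatic carbon gives a number 11.4 percentage points lower from compound 1 to compound 4 (beyond the scatter), which makes this the first change on the shared core whose size can be read. The step from compound 2 to compound 4 cannot be read, as compound 2 carries no number, and no measurement on hand accounts for the difference between the chloro and methoxy esters.

With only chloro and methoxy compared on the core of compound 1, these compounds cannot show whether the lower number for compound 4 would extend to other groups, such as a fluoro, a nitrile, an amine or a carboxylic acid, in the place of that chloro. They also leave open whether the number for compound 4 would hold if an amide replaced the ester linking the 4-chlorophenyl to the shared core.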